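This account rests on a few compounds, and the source may have more. Where it says the series, first, only, none or still open, it means among the compounds named here.

In an ADME assay on microsomes from liver (Rattus norvegicus) for metabolic stability, read by LC-MS, using NADPH (on this read-out higher numbers stand for a longer-lived compound and lower numbers for a shorter-lived compound), the measured compounds are:
compound 1 `O=C(NCCCCN1CCN(c2cccc(Cl)c2)CC1)c1ccc(-c2ccsc2)cc1` gives 0.468 h;
compound 2 `O=C(NCCCCN1CCN(c2ccccc2O)CC1)c1ccc(-c2ccsc2)cc1` gives 0.157 h;
compound 3 `O=C(NCCCCN1CCN(c2ccccc2C(F)(F)F)CC1)c1ccc(-c2ccsc2)cc1` gives 0.0667 h.

Compound 3 stands lowest of the three, as shown by a 2.4-fold lower number from compound 2 to compound 3 (0.37 log units; beyond the scatter) and by a 7.0-fold lower number from compound 1 to compound 3 (0.85 log units; beyond the scatter). Compound 4 `O=C(NCCCCN1CCN(c2ccc(C(F)(F)F)cc2)CC1)c1ccc(-c2ccsc2)cc1` differs from compound 3 in one place: 4-(trifluoromethyl)phenyl in place of 2-(trifluoromethyl)phenyl on an amine nitrogen in a ring. Going by the values given here, neither measured step keeps the same atoms and joins them differently; both steps that reach compound 3 exchange one group for another, so no measured step bears directly on this change. Since the atoms stay the same, the expected step of a 1.5-fold higher number from compound 3 to compound 4 (0.18 log units; within the scatter) is none beyond the scatter, with the direction uncertain. Compound 4 is therefore estimated at 0.1 h, with a range from 0.03 h to 0.3 h.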

Compound 4, half-life: > 1 h
Compound 4: no number, only a limit; the forecaster's own chance of this, stated with the estimate: 5%; at least 10-fold (1.00 log units) between middle value and limit.
By their numbers in this assay, from the lowest: compound 3; then compound 2; then compound 1. At a limit, above all of these: compound 4.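

Compound 4 carries only a limit of the assay, not a number: the limit of > 1 h in this assay, at which 1 of the 4 values shown sits. The earlier steps shown here all exchanged one group for another, whereas here the same atoms joined differently give an at least 14-fold higher number from compound 3 to compound 4 (1.17 log units; beyond the scatter), so on this amine nitrogen the arrangement of the trifluoromethylphenyl group alone can move the half-life strongly. The same compound also ends beyond the other two, with an at least 6.3-fold higher number from compound 2 to compound 4 (0.80 log units; beyond the scatter) and an at least 2.1-fold higher number from compound 1 to compound 4 (0.32 log units; beyond the scatter).

Going by these compounds, how far compound 4 lies past its limit stays open. So does whether a nitrile or a carboxylic acid in place of trifluoromethyl on this phenyl ring would give a similarly long half-life.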